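The compounds below may be only part of what the source reports. "The series", "measured", "known", "first", "only" and "open" are said of these compounds alone.

In an assay on liver for inhibition of sterol O-acyltransferase 1 (Rattus norvegicus), using microsomes (a lower number here means a stronger inhibitor, a higher number a weaker inhibitor), compound 1 `CC(C)c1cccc(C(C)C)c1NC(=O)NS(=O)(=O)N(C(C)C)C(C)(C)C` gives 140 nM, and compound 2 `CC(C)c1cccc(C(C)C)c1OS(=O)(=O)NC(=O)OC1[C@H](C(C)C)CCC[C@H]1C(C)C` gives 5700 nM. Compound 3 `COc1cc(C(C)C)c(OC(=O)NS(=O)(=O)Oc2c(C(C)C)cccc2C(C)C)c(C(C)C)c1` stands apart: in this assay it reaches only the limit of > 25000 nM, so no exact number is known for it, as noted in the limit of > 25000 nM in this assay, at which 1 of the 3 values shown sits. Compound 4 `CC(C)c1cc(F)cc(C(C)C)c1OC(=O)NS(=O)(=O)Oc1c(C(C)C)cccc1C(C)C` is compound 3 with a single change: fluoro in place of methoxy on an aromatic carbon. Going by the values given here, no pair of measured compounds shows this change, so its effect cannot be read from the data; the step is expected to be small, in either direction or none beyond the usual scatter. Compound 4 is therefore estimated at 20000 nM, with a likely range from 6000 nM to 60000 nM. This amounts to an expected step of an at least 1.2-fold lower number from compound 3 to compound 4 (0.09 log units; that floor lies within the scatter).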

Compound 4, half-maximal inhibitory concentration: > 50000 nM
Compound 4: only a limit was reported (the forecaster's own chance of this, stated with the estimate: 55%); middle value at least 2.5-fold (0.39 log units) from the limit.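

No step can be read between compound 3 and compound 4, as each has only a limit, not a number, in this assay. The compounds shown leave open whether fluoro in place of methoxy changes inhibition at all.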